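A few compounds are considered here, and "the series" means these few. Any claim that something is new, unique, unknown or untested is made for them only; others in the source may bear on it.

Compound 1 `COc1cc(CNC(=O)CCCCCCC(C)C)ccc1OC(=O)CCC(=O)Oc1ccc(C(N)=S)cc1`: "not determined" (no result reported)
Compound 2 `COc1cc(CNC(=O)CCCCCCC(C)C)ccc1OCCCCOc1ccc(-c2cc(=S)ss2)cc1`: > 50000 nM

Compound 1, `COc1cc(CNC(=O)CCCCCCC(C)C)ccc1OC(=O)CCC(=O)Oc1ccc(C(N)=S)cc1`, has no number in a functional assay on K562 cells (Homo sapiens) for antiproliferative activity, read by MTT assay, with a stated time of 48 h; a higher number here means a weaker inhibitor, a lower number a stronger inhibitor: for compound 1 this assay records "not determined" (no result reported). Among the compounds with values here, compound 2, `COc1cc(CNC(=O)CCCCCCC(C)C)ccc1OCCCCOc1ccc(-c2cc(=S)ss2)cc1`, shares much of its structure with compound 1 but differs in more than one place, so no single step can be drawn between them. Compound 2 gives > 50000 nM in this assay, which is a limit of the assay and not a number. That is the situation described by the limit of > 50000 nM in this assay, at which 1 of the 2 values shown sits. Compound 1 therefore stands nowhere on a scale: nothing measured sits on either side of it.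

Compound 3, `COc1cc(CNC(=O)CCCC/C=C/C(C)C)ccc1OC(=O)CCC(=O)Oc1ccc(C(N)=S)cc1`, is the compound still to be measured. It differs from compound 1 in a single place: 3-methylbut-1-en-1-yl in place of isopentyl on a saturated chain carbon, four bonds along the chain from a carbonyl carbon. Everything else in the molecule stays the same. Within the data shown here, with no measured step to lean on, the change from compound 1 to compound 3 is expected to shift the result by no more than the usual scatter, in no particular direction. Compound 3 is estimated at 30000 nM in this assay, with a likely range from 8000 nM to 150000 nM, and a fair chance that only a limit is reported.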

Compound 3, half-maximal inhibitory concentration: > 50000 nM
Compound 3 gave a limit, no number (the forecaster's own chance of this, stated with the estimate: 50%); middle value at least 1.6-fold (0.22 log units) away from the limit.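

No step can be read between compound 1 and compound 3: compound 1 has no result in this assay, and compound 3 gives only a limit of the assay, not a number. The compounds shown leave open whether 3-methylbut-1-en-1-yl in place of isopentyl changes the result at all, and the values so far rest here: the limit of > 50000 nM in this assay, at which 2 of the 3 values shown sit.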